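A few compounds are considered here, and "the series" means these few. Any claim that something is new, unique, unknown or untested is made for them only; others in the source may bear on it.

Measured compounds:
- compound 1, `COc1cc2nccc(Oc3ccc4c(NC(=O)c5cccc(C(F)(F)F)c5)nn(C)c4c3)c2cc1OC`: > 1000 nM
- compound 2, `COc1cc2nccc(Oc3ccc4c(NC(=O)C5CC5)nn(C)c4c3)c2cc1OC`: > 1000 nM
- compound 3, `COc1cc2nccc(Oc3ccc4c(NC(=O)c5cc(Cl)ccn5)nn(C)c4c3)c2cc1OC`: > 1000 nM

In a functional assay on HUVEC cells (Homo sapiens) for inhibition, with stated times of 2 h and 72 h (on this read-out higher numbers stand for weaker inhibition and lower numbers for stronger inhibition), compound 1 gives > 1000 nM, which is a limit of the assay rather than a number. Compound 2 gives > 1000 nM, again a limit. Compound 3 gives > 1000 nM, also a limit. All three sit at the limit of > 1000 nM in this assay, at which 3 of the 3 values shown sit, so compound 1 cannot be placed relative to the other two. Among the compounds with values here, the step that the two limits leave unreadable from compound 1 to compound 2 and the step that the two limits leave unreadable from compound 1 to compound 3 show only that swapping the group on the carbonyl carbon leaves every compound at the limit. Compound 4, `COc1ccc(Nc2nn(C)c3cc(Oc4ccnc5cc(OC)c(OC)cc45)ccc23)cc1`, differs from compound 1 by 4-methoxyphenyl in place of (3-(trifluoromethyl)phenyl)carbonyl on a nitrogen on an aromatic ring. Within the data shown here, no measured step covers a change of this kind, so no direction can be read from the data. Compound 4 is expected to remain weak, estimated at 3000 nM with a range from 800 nM to 20000 nM. That estimate means an expected step that the limit leaves unreadable from compound 1 to compound 4.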

Compound 4, half-maximal inhibitory concentration: > 1000 nM
Compound 4 gave a limit, no number (the forecaster's own chance of this, stated with the estimate: 70%); the middle value is on the limit's open side.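

No step from compound 1, compound 2 or compound 3 to compound 4 can be read, because all four values are limits rather than numbers: the limit of > 1000 nM in this assay, at which 4 of the 4 values shown sit.

On these data alone, whether any of the groups changed here affects inhibition in this assay remains open.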